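Compound 4: swapping the amide group of compound 2

The source may report more compounds than this note shows. Statements on the series, on what has been measured and on what is new or still open speak of the compounds shown alone.

Compound 1 `Cc1ccc(NC(=O)c2c(NO)cc(-c3ccc(F)cc3)oc2=O)cc1`: > 20000 nM
Compound 2 `Cc1ccc(NC(=O)c2c(NO)cc(-c3ccc(Cl)cc3)oc2=O)cc1`: > 20000 nM
Compound 3 `Cc1ccc(NC(=O)c2c(NO)cc(-c3ccc(C)cc3)oc2=O)cc1`: > 20000 nM

These three entries come from an ADME assay on Huh-7 cells (Homo sapiens) for cytotoxicity, read by a luciferase reporter and WST assay, with a stated time of 3 days (a higher number here means that more compound is tolerated, a lower number that less compound is tolerated), and each one is a limit of the assay, not a number. Compound 2 therefore has no exact place on the scale, and the same limit recurs across the set: the limit of > 20000 nM in this assay, at which 3 of the 3 values shown sit.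

Compound 4 `COC(=O)CNC(=O)c1c(NO)cc(-c2ccc(Cl)cc2)oc1=O` carries (methoxycarbonyl)methyl in place of 4-methylphenyl on an amide-type nitrogen.

Three measured steps are available: a step that the two limits leave unreadable from compound 1 to compound 2, a step that the two limits leave unreadable from compound 1 to compound 3 and a step that the two limits leave unreadable from compound 2 to compound 3. All three change a group on an aromatic carbon, none changes the group on the nitrogen, and none has a readable size. They offer only weak guidance, so the expectation rests on all three compounds sharing one limit. No step beyond the usual scatter is expected in this assay, and the estimated step is a step that the limit leaves unreadable from compound 2 to compound 4. The estimate for compound 4 is 25000 nM, with an expected range from 10000 nM to 50000 nM.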

Compound 4, half-maximal cytotoxic concentration: > 20000 nM
Compound 4 ended at the assay's limit (the forecaster's own chance of this, stated with the estimate: 85%); the middle value lies beyond the limit too.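

Compound 2 and compound 4 each give only a limit, not a number, so no step between them can be read: the limit of > 20000 nM in this assay, at which 4 of the 4 values shown sit.

The compounds shown leave open where any of them would give a real number in this assay, and whether the swap on the amide-type nitrogen changes that number.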